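This account rests on a few compounds, and the source may have more. Where it says the series, first, only, none or still open, it means among the compounds named here.

The measured compounds:

compound 1, `C=C(Br)C(=O)Nc1cccc(-c2cn3nc(-c4ccc(OCC)cc4)sc3n2)c1`, 1100 nM in a functional assay on FM3A cells (Mus musculus) for inhibition, read by cell counting, with a stated time of 2 days; a lower number here means a stronger inhibitor, a higher number a weaker inhibitor
compound 2, `C=C(Br)C(=O)Nc1cccc(-c2cn3c(-c4ccccc4)csc3n2)c1`, 1300 nM in this assay
compound 3, `Nc1cccc(-c2cn3c(-c4ccccc4)csc3n2)c1`, 34000 nM in this assay

Of these three numbers, those of compound 1 and compound 2 fall within the scatter of one another, while compound 3 lies well beyond both. The one step that is shown, a 26-fold higher number from compound 2 to compound 3 (1.42 log units; beyond the scatter), concerns the group on the ring nitrogen, not the aromatic group on the core, so it does not bear directly on the change considered here. Compound 4, `C=C(Br)C(=O)Nc1cccc(-c2cn3nc(Cc4ccccc4)sc3n2)c1`, differs from compound 1 by benzyl in place of 4-ethoxyphenyl on an aromatic carbon. Among the measured compounds shown here, no measured step addresses this position; the only hint comes from compound 1 and compound 2, whose values sit within the scatter despite their different cores and aromatic groups, which suggests that this part of the molecule tolerates variation. The step of a 1.4-fold higher number from compound 1 to compound 4 (0.13 log units; within the scatter) is therefore expected to stay within the scatter. Compound 4 is estimated at 1500 nM in this assay, with a range from 500 nM to 5000 nM.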

Compound 4, half-maximal inhibitory concentration: 3000 nM
The estimate for compound 4 lay 2.0-fold (0.30 log units) below the measured number; the range from low to high includes it.
By their numbers in this assay, from the lowest: compounds 1 and 2 (each within the scatter of the next); then compound 4; then compound 3.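

In this assay, among the compounds shown here, benzyl in place of 4-ethoxyphenyl gives a 2.7-fold higher number from compound 1 to compound 4 (0.44 log units; beyond the scatter), the first measured step at this aromatic carbon of the five-membered ring. For the compounds shown here, it shows that this position is not indifferent to the group it carries, which the earlier compounds could not show, though the modest size of the step means that benzyl is still accepted there with a limited loss. Nothing at hand explains the step.

The change alters both the ethoxy substituent and the way the benzene ring is attached, and the compounds shown do not separate the two. Going by these compounds, whether a plain phenyl, a 4-methoxyphenyl or an amine on this carbon would stay nearer to compound 1 or to compound 4 remains open.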